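A few compounds are considered here, and "the series" means these few. Any claim that something is new, unique, unknown or untested is made for them only; others in the source may bear on it.

Measured so far:
compound 1, `CC1=C(C(=O)Nc2ccc(Cl)cc2)C(c2ccncc2)C(C(=O)Nc2ccc(Cl)cc2)=C(C)N1`, 78 ug/mL;
compound 2, `CC1=C(C(=O)Nc2ccc(Cl)cc2)C(c2cccc(Cl)c2)C(C(=O)Nc2ccc(Cl)cc2)=C(C)N1`, 12 ug/mL.

In an ADME assay on Vero cells (Chlorocebus sabaeus) for cytotoxicity, read by sulforhodamine B assay, with a stated time of 3 days (a lower number here means that less compound is tolerated, a higher number that more compound is tolerated), compound 2 holds the lowest of the two numbers; its nearest neighbour is compound 1, and the step of a 6.5-fold lower number from compound 1 to compound 2 (0.81 log units; beyond the scatter) is the only one measured in the series. Compound 3, `CC1=C(C(=O)Nc2ccc(Cl)cc2)C(C/C=C/c2ccccc2)C(C(=O)Nc2ccc(Cl)cc2)=C(C)N1`, has not been measured in this assay. It differs from compound 2 in one place: 3-phenylprop-2-en-1-yl in place of 3-chlorophenyl on a saturated ring carbon.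

Within the data shown here, the one measured step exchanged one aromatic ring for another on the same saturated ring carbon and lowered the number beyond the scatter. Among the measured compounds shown here, no measured pair exchanges an aromatic ring for a 3-phenylprop-2-en-1-yl chain at that carbon, so the step of a 6.5-fold lower number from compound 1 to compound 2 (0.81 log units; beyond the scatter) bears on the present change only in showing that this position can move the number by a modest amount. For the measured compounds named here, with no closer precedent, a step near compound 2 in either direction, or none beyond the scatter, is the expectation.

Compound 3 is therefore estimated at 15 ug/mL in this assay, with a range of 5 ug/mL to 45 ug/mL, meaning an expected step of a 1.3-fold higher number from compound 2 to compound 3 (0.10 log units; within the scatter).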

Compound 3, half-maximal cytotoxic concentration: 21 ug/mL
Compound 3: the middle estimate sits 1.4-fold (0.15 log units) below what was measured, and the stated range covers the measured number.
By their numbers in this assay, from the lowest: compounds 2 and 3 (each within the scatter of the next); then compound 1.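

In this assay, the 3-chlorophenyl group and the 3-phenylprop-2-en-1-yl group cannot be separated at this saturated ring carbon, with a 1.8-fold higher number from compound 2 to compound 3 (0.24 log units; within the scatter); the change adds two heavy atoms and a double bond outside aromatic rings, and removes the chlorine, without a step beyond the scatter. The second comparison gives a 3.7-fold lower number from compound 1 to compound 3 (0.57 log units; beyond the scatter), so among the three compounds, the two with carbon-only aromatic groups at this position both stand apart from compound 1, which carries pyridin-4-yl. No measurement at hand accounts for this separation.

Going by these compounds, it remains open whether a ring nitrogen placed elsewhere, as in pyridin-3-yl, would give a number near that of compound 1. Also open, on these data alone, is how a saturated 3-phenylpropyl chain, or a chain ending in an amine or a carboxylic acid, would read at this carbon.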